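Amide substituent change in a vinyl dihydrofuran series

The source may hold more compounds than are shown below. What is called first, only, known or untested is meant among the compounds shown, and "the series" means these compounds.

Compound 1 `C=CC1=C(C(=O)NC(C)(C)C)C(c2ccc(OC)cc2)OC1` and compound 2 `C=CC1=C(C(=O)NC(C)(C)C)C(c2ccc(F)cc2)OC1` share the same core and differ only in the aromatic substituent. In a functional assay on HeLa cells (Homo sapiens) for cytotoxicity, read by MTT assay, with a stated time of 24 h (a higher number here means a weaker inhibitor, a lower number a stronger inhibitor), compound 1 gives > 100000 nM, which is a limit of the assay and not a number. Compound 2 in this assay gives > 100000 nM, likewise a limit. The step that the two limits leave unreadable from compound 1 to compound 2 cannot be sized because both values sit at the limit of > 100000 nM in this assay, at which 2 of the 2 values shown sit. Among the compounds with values here, compound 3 `C=CC1=C(C(=O)NC2CCCCC2)C(c2ccc(OC)cc2)OC1` differs from compound 1 by cyclohexyl in place of tert-butyl on an amide-type nitrogen, a change at the amide-type nitrogen that no measured pair covers, since the single measured step concerns the aromatic substituent only. Within the data shown here, with compound 1 at the limit and no measured step bearing on the amide change, the expected step in this assay is a number no higher from compound 1 to compound 3 (the limit leaves the size open), none readable beyond the scatter. Compound 3 is accordingly estimated at 100000 nM, with a range from 40000 nM to 300000 nM.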

Compound 3, half-maximal inhibitory concentration: 24800 nM
For compound 3 the middle estimate is 4.0-fold (0.61 log units) above the measured one; measured number below the stated range.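

In this assay, the amide-type nitrogen proves to be a position that can move the read-out: cyclohexyl in place of tert-butyl gives an at least 4.0-fold lower number from compound 1 to compound 3 (0.60 log units; beyond the scatter). Compound 3 is the first compound shown with a number and not a limit, so the series now has a value against which further steps can be sized. The step can only be given as a minimum, since compound 1 stands at a limit: the limit of > 100000 nM in this assay, at which 2 of the 3 values shown sit.

On these data alone, whether cyclohexyl on the amide-type nitrogen would shift the read-out in the same way for the fluoro compound, compound 2, remains open, and so does whether fluoro in place of methoxy can be read at all on a cyclohexyl amide. Also open, as far as these compounds go, is how a benzyl group or a longer straight chain on that nitrogen would read in this assay.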